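The compounds below may be only part of what the source reports. "The series", "measured", "known", "first", "only" and "open" are said of these compounds alone.

Within the data shown here, in an assay on cells for agonist activity at vitamin D3 receptor (Homo sapiens), read by microscopy (on this read-out higher numbers stand for an effect only at larger amounts of compound and lower numbers for an effect already at smaller amounts), compound 2 `CCn1cc(C(CC)(CC)c2ccc(C#CC(O)(CC)CC)c(C)c2)cc1C(=O)N[C@H](C(=O)O)C(C)C` gives 12.7 nM, the lower of the two numbers measured so far. Compound 1 `CCn1cc(C(CC)(CC)c2ccc(C#CC(O)(CC)CC)c(C)c2)cc1C(=O)NCC(=O)O` gives 54.3 nM. Among the measured compounds shown here, the only measured step is a 4.3-fold lower number from compound 1 to compound 2 (0.63 log units; beyond the scatter), and it concerns the same nitrogen substituent that is altered next. Compound 3 `CCn1cc(C(CC)(CC)c2ccc(C#CC(O)(CC)CC)c(C)c2)cc1C(=O)N[C@@H](C)CO` is the next entry: 1-(hydroxymethyl)ethyl in place of 1-carboxy-2-methylpropyl on an amide-type nitrogen. For the measured compounds named here, this change takes away the isopropyl whose introduction produced the step from compound 1 to compound 2, and at the same time exchanges the carboxylic acid for a hydroxymethyl group; no measured pair speaks to that second exchange. Undoing the isopropyl gain alone would point to a rise of roughly the size seen between compound 1 and compound 2, so for compound 3 the expected step is a 7.1-fold higher number from compound 2 to compound 3 (0.85 log units; beyond the scatter), towards a higher number, with wide uncertainty. The estimate for compound 3 is 90 nM, expected to fall between 25 nM and 400 nM.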

Compound 3, half-maximal effective concentration: 7.33 nM
Compound 3: middle estimate off by 12-fold (1.09 log units), on the high side; measured number below the stated range.
By their numbers in this assay, from the lowest: compounds 3 and 2 (each within the scatter of the next); then compound 1.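

The step of a 1.7-fold lower number from compound 2 to compound 3 (0.24 log units; within the scatter) shows that in this assay the amide-type nitrogen tolerates the loss of both the carboxylic acid and the isopropyl branch together, so a carboxylic acid is not required on this substituent for a value in this range. The step of a 7.4-fold lower number from compound 1 to compound 3 (0.87 log units; beyond the scatter) adds that 1-(hydroxymethyl)ethyl, which carries no carboxylic acid, also departs from carboxymethyl beyond the scatter, so isopropyl is not the only substituent on this carbon linked to such a departure. No supporting measurement is available to explain these results.

Among these compounds, the two exchanges in the step to compound 3 remain unseparated, since no pair here changes the carboxylic acid to hydroxymethyl while keeping the rest of the substituent. As far as these compounds go, whether a primary amine or a longer hydroxyalkyl chain would be tolerated at this nitrogen also remains open.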